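Methoxy in place of trifluoromethyl on the benzyl group

A few compounds are considered here, and "the series" means these few. Any claim that something is new, unique, unknown or untested is made for them only; others in the source may bear on it.

In a functional assay on HPAC cells (Homo sapiens) for inhibition, read by MTT assay, with a stated time of 72 h (on this read-out lower numbers stand for stronger inhibition of growth and higher numbers for weaker inhibition of growth), compound 3 `O=S(=O)(NCCCNCc1ccc(C(F)(F)F)cc1)c1cc(C(F)(F)F)cc(C(F)(F)F)c1` gives 2700 nM, the lowest of the three numbers. Compound 2 `O=S(=O)(NCCCNCc1ccc(Cl)c(C(F)(F)F)c1)c1cc(C(F)(F)F)cc(C(F)(F)F)c1` gives 3000 nM, and a 1.1-fold lower number from compound 2 to compound 3 (0.05 log units; within the scatter). Compound 1 `O=S(=O)(NCCCNCc1ccccc1Cl)c1cc(C(F)(F)F)cc(C(F)(F)F)c1` gives 10000 nM, and a 3.7-fold lower number from compound 1 to compound 3 (0.57 log units; beyond the scatter). Compound 4 `COc1ccc(CNCCCNS(=O)(=O)c2cc(C(F)(F)F)cc(C(F)(F)F)c2)cc1` differs from compound 3 by methoxy in place of trifluoromethyl on an aromatic carbon. Going by the values given here, no measured step exchanges these two groups. The measured steps that touch this ring are a 3.3-fold lower number from compound 1 to compound 2 (0.52 log units; beyond the scatter) and a 3.7-fold lower number from compound 1 to compound 3 (0.57 log units; beyond the scatter), both modest, and a step that removed a chloro while keeping the trifluoromethyl stayed within the scatter. A small step towards weaker inhibition, not clearly beyond the scatter, is therefore expected for compound 4: a 1.5-fold higher number from compound 3 to compound 4 (0.17 log units; within the scatter). The estimate for compound 4 in this assay is 4000 nM, within 1500 nM to 12000 nM.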

Compound 4, concentration for 50% growth inhibition: 3000 nM
The estimate for compound 4 lay 1.3-fold (0.12 log units) above the measured number; measured number inside the range.
By their numbers in this assay, from the lowest: compounds 3, 2 and 4 (each within the scatter of the next); then compound 1.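

In this assay, methoxy and trifluoromethyl read alike on this aromatic carbon para to a large group, with a 1.1-fold higher number from compound 3 to compound 4 (0.05 log units; within the scatter), and compound 4 also matches the chloro-bearing benzyl compound, with no change at the digits printed from compound 2 to compound 4 (within the scatter). The 2-chlorophenyl compound alone stands apart, with a 3.3-fold lower number from compound 1 to compound 4 (0.52 log units; beyond the scatter). No evidence is available to explain why the two groups read alike. Open, going by these compounds, is whether a hydroxyl or an amine on this carbon, or a longer chain in the shared core, would move the number beyond the scatter.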